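The compounds below may be only part of what the source reports. "The series", "measured", "known", "first", "only" and "open" are said of these compounds alone.

In a functional assay on HCT-116 cells (Homo sapiens) for antiproliferative activity, read by MTT assay (on this read-out lower numbers stand for stronger inhibition and higher numbers for weaker inhibition), compound 1 (`Cn1c(=O)c(=O)n(C2CCCC2)c2nc(N/N=C/c3ccccc3)ncc21`) gives > 100000 nM as a limit of the assay and not a number. Compound 2 (`Cn1c(=O)c(=O)n(C2CCCC2)c2nc(N/N=C/c3ccc(S(C)(=O)=O)cc3)ncc21`) gives 86600 nM and so holds the higher of the two actual numbers. Compound 3 (`Cn1c(=O)c(=O)n(C2CCCC2)c2nc(N/N=C/c3cc(C(F)(F)F)c(O)c(C(F)(F)F)c3)ncc21`) gives 27100 nM as the lower one, a gap beyond the scatter. Compound 4 (`Cn1c(=O)c(=O)n(C2CCCC2)c2nc(N/N=C/c3cccs3)ncc21`) has not yet been measured. Going from compound 2 to compound 4 puts thiophen-2-yl in place of 4-(methylsulfonyl)phenyl on a carbon with a double bond to nitrogen. For the measured compounds named here, the only measured step that bears on this is an at least 1.1-fold lower number from compound 1 to compound 2 (0.06 log units; that floor lies within the scatter) for methylsulfonyl in place of hydrogen on an aromatic carbon. Its floor lies within the scatter, and it starts from a limit. Going by the values given here, no measured compound carries thiophen-2-yl, so this is a weak guide, and a reading that is only a limit remains possible. The expected step is a 1.0-fold higher number from compound 2 to compound 4 (0.02 log units; within the scatter) and no change beyond the scatter is expected in either direction. The estimate for compound 4 is 90000 nM (expected range 40000 nM to 160000 nM).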

Compound 4, half-maximal inhibitory concentration: 52600 nM
Beside the measured number, compound 4's estimate is 1.7-fold (0.23 log units) above it; the measured number falls inside the stated range.
By their numbers in this assay, from the lowest: compounds 3, 4 and 2 (each within the scatter of the next, the first and the last beyond it). At a limit, above all of these: compound 1.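

In this assay, putting thiophen-2-yl in place of 4-(methylsulfonyl)phenyl on this carbon gives a 1.6-fold lower number from compound 2 to compound 4 (0.22 log units; within the scatter), so the methylsulfonyl group and the six-membered ring are not needed for an actual number to appear here. Set against plain phenyl, the same five-membered ring gives an at least 1.9-fold lower number from compound 1 to compound 4 (0.27 log units; that floor lies within the scatter). The true size of that second step cannot be read because compound 1 stands at a limit of the assay and not a number: the limit of > 100000 nM in this assay, at which 1 of the 4 values shown sits.

On these data alone, whether the sulfur atom or the five-membered ring shape matters at this carbon stays open, and a comparison of thiophen-2-yl with thiophen-3-yl, furan-2-yl or a pyridine ring would help to separate the two. As far as these compounds go, it also remains open whether an amine or a chlorine on the thiophene ring would shift the number beyond the scatter.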